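This account rests on a few compounds, and the source may have more. Where it says the series, first, only, none or still open, it means among the compounds named here.

Measured compounds in a functional assay on DU-145 cells (Homo sapiens) for inhibition, read by trypan blue exclusion, with a stated time of 96 h; on this read-out lower numbers stand for stronger inhibition of growth and higher numbers for weaker inhibition of growth:
compound 1 `O=C(/C(=C\c1ccc(Cl)cc1)S(=O)(=O)c1ccc(Br)cc1)c1ccc(Br)cc1` gives 50000 nM
compound 2 `COc1ccc(/C=C(\C(=O)c2ccc(Br)cc2)S(=O)(=O)c2ccc(Br)cc2)cc1` gives 25000 nM
compound 3 `COc1ccc(C(=O)/C(=C\c2ccc(Cl)cc2)S(=O)(=O)c2ccc(Cl)cc2)cc1` gives 4000 nM

The difference between compound 2 and compound 3 is not broken down here; the two differ in more than one place. For the measured compounds named here, the only counted step among the measured compounds is chloro in place of methoxy on an aromatic carbon, which gave a 2.0-fold higher number from compound 2 to compound 1 (0.30 log units; within the scatter).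

Compound 4 `O=C(/C(=C\c1ccc(Cl)cc1)S(=O)(=O)c1ccc(Cl)cc1)c1ccc(Cl)cc1` is not yet measured. It arises from compound 3 by chloro in place of methoxy on an aromatic carbon, the same change as that from compound 2 to compound 1, at a place described in the same words. The expectation for compound 4 therefore rests on compound 3 and its value 4000 nM, shifted by a step like a 2.0-fold higher number from compound 2 to compound 1 (0.30 log units; within the scatter). In this assay the step from compound 3 to compound 4 is expected to be a 2.0-fold higher number from compound 3 to compound 4 (0.30 log units; within the scatter), a small move since the earlier step lay within the scatter. Compound 4 is estimated at 8000 nM, between 2500 nM and 25000 nM.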

Compound 4, concentration for 50% growth inhibition: 25000 nM
Compound 4: the middle estimate sits 3.1-fold (0.49 log units) below what was measured, and the stated range covers the measured number.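

In this assay the change from 4-methoxyphenyl to 4-chlorophenyl gave a 6.3-fold higher number from compound 3 to compound 4 (0.80 log units; beyond the scatter). The size of this step did not carry over from one core to the other: the same change on two cores in this assay, a 2.0-fold higher number (0.30 log units; within the scatter) from compound 2 to compound 1 and a 6.3-fold higher number (0.80 log units; beyond the scatter) from compound 3 to compound 4, 3.1-fold (0.49 log units) apart, beyond the scatter of two such steps. For the compounds shown here, with a single pair on each core, this shows only that the step cannot be assumed to have one size across these two cores; it does not show which difference between the cores goes with the gap, or how the step would run on a further core.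

Open, going by these compounds, is how an amine or a carboxylic acid at the same place would read on either core. Also open, on these data alone, is how the step would run on a core with one bromo and one chloro on its other two aromatic rings.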